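The source may report more compounds than this note shows. Statements on the series, on what has been measured and on what is new or still open speak of the compounds shown alone.

In a functional assay on HT-29 cells (Homo sapiens) for cytotoxicity, read by sulforhodamine B assay (a higher number here means that more compound is tolerated, a lower number that less compound is tolerated), compound 1 `COC1=C(Br)[C@H](O)[C@@]2(C=C1Br)CC(C(=O)NCCCCCNC(=O)C1=NO[C@]3(C=C(Br)C(=O)[C@@H](Br)[C@@H]3O)C1)=NO2` gives 9100 nM. Compound 3 `COC1=C(Br)[C@H](O)[C@@]2(C=C1Br)CC(C(=O)NCCCCNC(=O)C1=NO[C@]3(C=C(Br)C(=O)[C@@H](Br)[C@@H]3O)C1)=NO2` gives 11300 nM, which lies within the scatter of compound 1, while compound 2 `O=C(NCCCCCNC(=O)C1=NO[C@]2(C=C(Br)C(=O)[C@@H](Br)[C@@H]2O)C1)C1=NO[C@]2(C=C(Br)C(=O)[C@@H](Br)[C@@H]2O)C1` gives 3000 nM, a lower number beyond the scatter. Compound 4 `COC1=C(Br)[C@H](O)[C@@]2(C=C1Br)CC(C(=O)NCCCCCNC(=O)C1=NO[C@]3(C=C(Br)C(=O)[C@H](Br)[C@@H]3O)C1)=NO2` has not yet been measured. Set against compound 1, it shows this change: the two compounds have the same atoms and bonds and differ only in configuration as drawn: 1 of 5 stereo elements differ; a stereocentre at a saturated ring carbon is drawn S in compound 1 and R in compound 4. Among the measured compounds shown here, no measured pair here isolates a change of this kind, so the data give no direct guide to its size. In this assay, no step beyond the scatter is expected, although a move in either direction remains possible. The estimated step is a 1.1-fold higher number from compound 1 to compound 4 (0.04 log units; within the scatter). For compound 4 the expected value is 10000 nM, with an estimated range from 4000 nM to 25000 nM.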

Compound 4, concentration lethal to 50% of the cells: 5400 nM
Compound 4: middle estimate off by 1.9-fold (0.27 log units), on the high side; the measured number falls inside the stated range.
By their numbers in this assay, from the lowest: compounds 2, 4, 1 and 3 (each within the scatter of the next, the first and the last beyond it).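

Inverting one stereocentre at a saturated ring carbon, drawn S in compound 1 and R in compound 4, gives a 1.7-fold lower number from compound 1 to compound 4 (0.23 log units; within the scatter) in this assay. Unlike the earlier compounds, this pair isolates a single change, so the step can be read on that stereocentre alone: the fact that compounds 1 and 4 differ only in the configuration as drawn. In this one pair, the configuration drawn at this position does not move the number beyond the scatter.

Going by these compounds, whether the same inversion would read alike on compound 2 or compound 3 stays open. So does the effect of a longer chain in place of the one in compound 1.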